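Bromo on the fused ring: a second instance

The source may report more compounds than this note shows. Statements on the series, on what has been measured and on what is new or still open speak of the compounds shown alone.

Compound 1 `O=C1N=C(N2N=C(c3ccccc3)CC2c2ccccc2O)S/C1=C1/C(=O)Nc2ccccc21` is the parent of the first pair. In a functional assay on cells (Cancer cell lines, Homo sapiens) for cytotoxicity, read by sulforhodamine B assay, with a stated time of 48 h (a higher number here means a weaker inhibitor of growth, a lower number a stronger inhibitor of growth), compound 1 gives 2130 nM. Compound 2 `O=C1N=C(N2N=C(c3ccccc3)CC2c2ccccc2O)S/C1=C1/C(=O)Nc2ccc(Br)cc21` carries the change (bromo in place of hydrogen on an aromatic carbon); in this assay compound 2 gives 240 nM, which is an 8.9-fold lower number from compound 1 to compound 2 (0.95 log units; beyond the scatter).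

Compound 3 `COc1ccc(C2CC(c3ccc4ccccc4c3)=NN2C2=NC(=O)/C(=C3\C(=O)Nc4ccccc43)S2)cc1` belongs to a different core; the difference between the core of compound 3 and the core of compound 1 is not broken down here. In this assay compound 3 gives 670 nM, between the two numbers of the first pair.

Compound 4 `COc1ccc(C2CC(c3ccc4ccccc4c3)=NN2C2=NC(=O)/C(=C3\C(=O)Nc4ccc(Br)cc43)S2)cc1` is not yet measured. It differs from compound 3 by bromo in place of hydrogen on an aromatic carbon, the same change, at the same place, that separates compound 2 from compound 1. Going by the values given here, the expectation rests on that single earlier step, because the step of an 8.9-fold lower number from compound 1 to compound 2 (0.95 log units; beyond the scatter) is the only measured instance of the change, and the second core may not answer to it in the same degree. For compound 4 in this assay the estimated step is a 6.1-fold lower number from compound 3 to compound 4 (0.78 log units; beyond the scatter). Compound 4 is therefore expected to give about 110 nM, plausibly between 40 nM and 320 nM.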

Compound 4, concentration for 50% growth inhibition: 46 nM
The estimate for compound 4 lay 2.4-fold (0.38 log units) above the measured number; measured number inside the range.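

In this assay, bromo in place of hydrogen on an aromatic carbon gives a 15-fold lower number from compound 3 to compound 4 (1.16 log units; beyond the scatter), so the change carries over to the second core in the same direction as on the first. The two instances agree in size once the usual scatter is allowed for, and no difference between them is to be read: the same change on two cores in this assay, an 8.9-fold lower number (0.95 log units; beyond the scatter) from compound 1 to compound 2 and a 15-fold lower number (1.16 log units; beyond the scatter) from compound 3 to compound 4, 1.6-fold (0.22 log units) apart, within the scatter of two such steps. This supports carrying the change between these two cores in this assay, but two instances do not establish a rule for other cores, and they do not show why the change has this effect.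

The compounds shown hold only hydrogen or bromo at this place, so it remains open whether chloro, a nitrile or an amine there would give a comparable step. Also open, from the compounds shown here alone, is whether the step would persist on a core bearing a carboxylic acid or a longer chain on its outer aromatic rings.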